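Compound 1 to compound 4: one methoxy removed

The source may report more compounds than this note shows. Statements on the series, on what has been measured and on what is new or still open speak of the compounds shown alone.

In a functional assay on HeLa cells (Homo sapiens) for cytotoxicity, read by WST assay, with a stated time of 48 h (a higher number here means a weaker inhibitor, a lower number a stronger inhibitor), compound 1 `COc1ccc([C@@H]2OC[C@H]([C@@H](O)c3ccc(OC)c(OC)c3)C[C@H]2C/C=C/c2ccc(OC)c(OC)c2)cc1` gives 29200 nM. Compound 2 `COc1ccc(/C=C/C[C@H]2C[C@@H]([C@@H](O)c3ccccc3)CO[C@@H]2c2ccc(OC)c(OC)c2)cc1OC` gives 15500 nM, and this value lies within the scatter of the value for compound 1, so the two cannot be ranked. Compound 3 `COc1ccc(/C=C/C[C@@H]2C[C@@H]([C@@H](OC)c3ccc(OC)c(OC)c3)CO[C@H]2c2ccc(OC)c(OC)c2)cc1OC` gives > 100000 nM, which is a limit of the assay and not a number.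

Compound 4 `COc1ccc(/C=C/C[C@@H]2C[C@@H]([C@@H](O)c3ccc(OC)c(OC)c3)CO[C@H]2c2ccccc2)cc1OC` departs from compound 1 at one place: hydrogen in place of methoxy on an aromatic carbon. It carries hydrogen in place of methoxy on an aromatic carbon, para to a large group, so 4-methoxyphenyl becomes phenyl.

Within the data shown here, no measured pair isolates this change, so the expectation has little to rest on. Among the measured compounds shown here, the only numerical anchors are compound 1 at 29200 nM and compound 2 at 15500 nM. In this assay no step beyond the scatter is expected, and no direction is favoured. The estimated change is a 1.3-fold lower number from compound 1 to compound 4 (0.12 log units; within the scatter). For compound 4 the expected value is 22000 nM, with an estimated range of 8000 nM to 70000 nM.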

Compound 4, half-maximal inhibitory concentration: 16100 nM
Compound 4: middle estimate off by 1.4-fold (0.14 log units), on the high side; the measured number falls inside the stated range.
By their numbers in this assay, from the lowest: compounds 2, 4 and 1 (each within the scatter of the next). At a limit, above all of these: compound 3.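

Hydrogen in place of methoxy gives a 1.8-fold lower number from compound 1 to compound 4 (0.26 log units; within the scatter), the first step in the series that isolates a single change. Compound 1 and compound 4 cannot be ranked, so in this assay the 4-methoxyphenyl and phenyl forms read alike at this place on the aromatic ring. Among these compounds, this shows only that the methoxy group is not needed to keep a value within the scatter of compound 1. Compounds 1 to 3 could not give this reading. None of them formed a pair differing in one place.

From the compounds shown here alone, whether an amine or a carboxylic acid at this place would separate from these values stays open. Compound 3 remains a limit and not a number, and no step to it can be read: the limit of > 100000 nM in this assay, at which 1 of the 4 values shown sits.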